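The compounds below may be only part of what the source reports. "The series", "measured", "known", "first", "only" and "open" are said of these compounds alone.

Compound 1 `COc1cc(/C=C/C(=O)C2=C(/C=C/c3ccc(O)c(OC)c3)NC(=O)NC2c2ccccc2)ccc1O` is the weaker of the two compounds measured in a functional assay, with a stated time of 20 min, tested at 50 uM (on this read-out higher numbers stand for a stronger effect at the one concentration tested and lower numbers for a weaker effect), where compound 1 gives 50.2%. Compound 2 `COc1cc(/C=C/C(=O)C2=C(/C=C/c3ccc(O)c(OC)c3)NC(=O)NC2c2ccc(O)cc2)ccc1O` gives 86.2%, and the step of a number 36 percentage points higher from compound 1 to compound 2 (beyond the scatter) came with a hydroxy in place of hydrogen on an aromatic carbon. Compound 3 `COc1cc(/C=C/C(=O)C2=C(/C=C/c3ccc(O)c(OC)c3)NC(=O)NC2c2cccc([N+](=O)[O-])c2)ccc1O` differs from compound 1 by nitro in place of hydrogen on an aromatic carbon. Going by the values given here, no measured step involves a nitro group, so the single measured step only shows that a new group on the shared core can move the read-out. For compound 3 a modest rise is expected, a number 9.8 percentage points higher from compound 1 to compound 3 (within the scatter), giving an estimated 60% with a range from 40% to 80%.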

Compound 3, a percentage reported as activity, at one concentration (the size of the read-out at that concentration, not a potency): 48%
The estimate for compound 3 lay 12 percentage points above the measured number; the range from low to high includes it.
By their numbers in this assay, from the lowest: compounds 3 and 1 (each within the scatter of the next); then compound 2.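

In this assay, nitro on this aromatic ring, meta to a large group, gives a number 2.2 percentage points lower from compound 1 to compound 3 (within the scatter), so adding a group here does not by itself raise the read-out. Replacing 4-hydroxyphenyl with 3-nitrophenyl gives a number 38.2 percentage points lower from compound 2 to compound 3 (beyond the scatter), so among the groups shown, only hydroxy accompanies a rise. Nothing available gives a reason for this difference between the two groups.

Hydroxy and nitro also sit at different places on the ring, so the effects of group and place cannot be separated. As far as these compounds go, whether an amine or a carboxylic acid would behave like hydroxy or like nitro also remains open.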